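This account rests on a few compounds, and the source may have more. Where it says the series, first, only, none or still open, it means among the compounds named here.

Compound 1 `COc1ccc(-c2cc(C(=O)Nc3nc4ccc(F)cc4s3)nc3cc(-c4ccccc4)nn23)cc1` is the weakest of the three measured compounds in a functional assay on ACHN cells (Homo sapiens) for cytotoxicity, read by MTT assay, with a stated time of 48 h (a lower number here means a stronger inhibitor, a higher number a weaker inhibitor), where compound 1 gives 39300 nM. Compound 2 `COc1ccc(-c2cc(C(=O)Nc3nc4ccc(F)cc4s3)nc3cc(-c4ccccc4)nn23)cc1OC` differs from compound 1 by one change, (methoxy in place of hydrogen on an aromatic carbon), and in this assay compound 2 gives 8120 nM, a step described as a 4.8-fold lower number from compound 1 to compound 2 (0.68 log units; beyond the scatter). Compound 3 `COc1ccc2nc(NC(=O)c3cc(-c4ccc(OC)c(OC)c4)n4nc(-c5ccccc5)cc4n3)sc2c1` carries a methoxy in place of fluoro on an aromatic carbon relative to compound 2 and in this assay compound 3 gives 13300 nM, a step described as a 1.6-fold higher number from compound 2 to compound 3 (0.21 log units; within the scatter). The difference between the core of compound 1 and the core of compound 3 is not broken down here.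

Compound 4 `COc1ccc2nc(NC(=O)c3cc(-c4cc(OC)c(OC)c(OC)c4)n4nc(-c5ccccc5)cc4n3)sc2c1` has not yet been measured. It differs from compound 3 by methoxy in place of hydrogen on an aromatic carbon. This is the same kind of change as that from compound 1 to compound 2, but the place is not identical: in compound 4 the entering methoxy is also meta to a methoxy group, which was not so in compound 2. On the strength of the step of a 4.8-fold lower number from compound 1 to compound 2 (0.68 log units; beyond the scatter), compound 4 is expected to show a step of a 2.4-fold lower number from compound 3 to compound 4 (0.38 log units; beyond the scatter) in this assay, somewhat smaller than the earlier one given the different surroundings. Compound 4 is thus estimated at 5500 nM, within 2000 nM to 15000 nM.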

Compound 4, half-maximal inhibitory concentration: 5240 nM
For compound 4 the middle estimate is 1.0-fold (0.02 log units) above the measured one; the range from low to high includes it.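

In this assay the change from 3,4-dimethoxyphenyl to 3,4,5-trimethoxyphenyl gives a 2.5-fold lower number from compound 3 to compound 4 (0.40 log units; beyond the scatter), so methoxy in place of hydrogen lowers the number on both cores, and the two steps cannot be told apart in size: the same change on two cores in this assay, a 4.8-fold lower number (0.68 log units; beyond the scatter) from compound 1 to compound 2 and a 2.5-fold lower number (0.40 log units; beyond the scatter) from compound 3 to compound 4, 1.9-fold (0.28 log units) apart, within the scatter of two such steps Within this series, then, the direction of the change carried over from one core to the other, and the data give no ground for saying that the core alters its size. Going by these compounds alone, this rests on only two pairs, however, so it does not show that the step would hold on any further core, nor can it separate the effect of the core from that of the different surroundings of the entering methoxy. The compounds shown leave open how an ethoxy group, a hydroxyl or an amine would behave in place of the entering methoxy. They also leave open whether the same step would appear in any cells other than those of this assay.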